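A few compounds are considered here, and "the series" means these few. Any claim that something is new, unique, unknown or untested is made for them only; others in the source may bear on it.

In a functional assay on HepG2 cells (Homo sapiens) for cytotoxicity, read by MTT assay, with a stated time of 48 h (a higher number here means a weaker inhibitor, a lower number a stronger inhibitor), compound 1 `CC1=NN(C(=O)CSc2ccccn2)[C@@H](c2cc(Br)cc(Br)c2O)C1` gives 24700 nM and compound 2 `O=C(CSc1ccc(Br)cc1)N1N=C(c2cc3ccccc3oc2=O)C[C@@H]1c1ccccc1C(F)(F)F` gives 17900 nM. These two values lie within the usual scatter of each other. Compound 3 `CC1=NN(C(=O)CSc2ccc(Br)cc2)[C@@H](c2cc(Br)cc(Br)c2O)C1` keeps the core of compound 1 and changes one group: 4-bromophenyl in place of pyridin-2-yl on a sulfur. Among the measured compounds shown here, no measured pair shows this change alone. Compound 2 carries the same 4-bromophenyl group and gives 17900 nM, so no shift beyond the scatter is expected. The expected step is a 1.4-fold lower number from compound 1 to compound 3 (0.14 log units; within the scatter). Compound 3 is estimated at 18000 nM, with an expected range of 7000 nM to 45000 nM.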

Compound 3, half-maximal inhibitory concentration: 6870 nM
Estimate against measurement, compound 3: 2.6-fold (0.42 log units) above; the measured number lies below the stated range.
By their numbers in this assay, from the lowest: compound 3; then compounds 2 and 1 (each within the scatter of the next).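

In this assay the group on the sulfur clearly matters for the core of compound 1: 4-bromophenyl in place of pyridin-2-yl gives a 3.6-fold lower number from compound 1 to compound 3 (0.56 log units; beyond the scatter) and this is the first single-place change shown. No measurement here offers an explanation for the step. Going by these compounds, this one swap both removes the ring nitrogen and adds the bromine, so the share of each stays open. Also open, on these data alone, is how plain phenyl, or a phenyl ring carrying an amine or a carboxylic acid in place of bromine, would compare.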